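The source may hold more compounds than are shown below. What is called first, only, known or untested is meant among the compounds shown, and "the series" means these compounds.

In an ADME assay on CHO cells (Cricetulus griseus) for cytotoxicity, read by MTT assay (on this read-out lower numbers stand for higher toxicity in this test and higher numbers for lower toxicity in this test), two compounds have been measured so far:

- compound 1 `C[C@@H]1CN(C(=O)c2ccnc(Nc3nc4cnc(Nc5cccc(C(F)(F)F)c5)cc4[nH]3)c2)C[C@H](C)N1` gives 37000 nM
- compound 2 `C[C@@H]1CN(C(=O)c2ccnc(Nc3nc4cnc(Nc5ccc(F)c(F)c5)cc4[nH]3)c2)C[C@H](C)N1` gives > 50000 nM, which is a limit and not a number

Compound 2 stands on (the limit of > 50000 nM in this assay, at which 1 of the 2 values shown sits).

Compound 3 `O=C(c1ccnc(Nc2nc3cnc(Nc4ccc(F)c(F)c4)cc3[nH]2)c1)N1CCC(F)(F)CC1` is the next compound to be tested. It differs from compound 2 at one place, with 4,4-difluoropiperidin-1-yl in place of 3,5-dimethylpiperazin-1-yl on a carbonyl carbon. The 2 defined stereocentres leave with the old ring.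

Among the compounds with values here, only one measured step can be consulted, an at least 1.3-fold higher number from compound 1 to compound 2 (0.13 log units; that floor lies within the scatter). That step lies at a different place, on a nitrogen on an aromatic ring, and its floor lies within the scatter. It therefore gives no size or direction for a change on the carbonyl carbon, and no step beyond the scatter is expected in this assay.

The expected change is an at least 1.1-fold lower number from compound 2 to compound 3 (0.04 log units; that floor lies within the scatter).

For compound 3 the estimated value is 45000 nM, with an expected range from 15000 nM to 100000 nM.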

Compound 3, half-maximal cytotoxic concentration: 29000 nM
Beside the measured number, compound 3's estimate is 1.6-fold (0.19 log units) above it, and the stated range covers the measured number.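

In this assay, within the data shown here, the change from 3,5-dimethylpiperazin-1-yl to 4,4-difluoropiperidin-1-yl on the carbonyl carbon gives the first reading at this position: an at least 1.7-fold lower number from compound 2 to compound 3 (0.23 log units; that floor lies within the scatter). Compound 2 has only a limit of the assay and not a number: the limit of > 50000 nM in this assay, at which 1 of the 3 values shown sits. The step is therefore known only as a floor, so the true gap may be larger, but its size cannot be read. Among these compounds, compound 3, at 29000 nM, gives the first actual number for a compound with the 3,4-difluorophenyl group.

The change removes a ring nitrogen, two methyl groups and both defined stereocentres and brings in two fluorine atoms, all at once, so the step cannot be tied to any one of these parts. From the compounds shown here alone, how a morpholine or an unsubstituted piperidine would read on the same carbonyl carbon remains open, as does whether this ring change would give a similar step with the 3-(trifluoromethyl)phenyl group of compound 1.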